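A Swap on the Benzylidene Arm and Its Expected Cost

This account rests on a few compounds, and the source may have more. Where it says the series, first, only, none or still open, it means among the compounds named here.

Compound 1 `C=CCn1c(=O)/c(=C\c2ccc(Cl)c(Cl)c2)[nH]c(=O)/c1=C\c1ccccc1OC`: in a functional assay on U-937 cells (Homo sapiens) for cytotoxicity, read by CCK-8 assay, with a stated time of 72 h (a lower number here means a stronger inhibitor, a higher number a weaker inhibitor), compound 1 gives "not active" (no number reported).
Compound 2 `C=CCn1c(=O)/c(=C\c2cc(Br)ccc2F)[nH]c(=O)/c1=C\c1ccccc1OC`: in this assay compound 2 gives 4700 nM.

Compound 2 carries the only numerical result here; compound 1 was reported without a number. Compound 3 `C=CCn1c(=O)/c(=C\c2ccc(C)cc2)[nH]c(=O)/c1=C\c1ccccc1OC` differs from compound 2 in one place: 4-methylphenyl in place of 5-bromo-2-fluorophenyl on a double-bonded chain carbon bound to an aromatic carbon. Among the measured compounds shown here, no measured pair shows what such a swap does, so the step from compound 2 to compound 3 is expected to be small to moderate toward weaker inhibition, a 1.7-fold higher number from compound 2 to compound 3 (0.23 log units; within the scatter), though it may fall within scatter. Compound 3 is estimated at 8000 nM in this assay, with a range from 2500 nM to 25000 nM.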

Compound 3, half-maximal inhibitory concentration: "not active" (no number reported)
Compound 3 has no reported number here, so the estimate cannot be set against anything.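

Compound 3, like compound 1, has no reported number, so no step from compound 2 to compound 3 can be read, and nothing available explains this result. In this assay, going by these compounds, it stays open how far 4-methylphenyl in place of 5-bromo-2-fluorophenyl shifts the number.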